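This account rests on a few compounds, and the source may have more. Where it says the series, first, only, none or still open, it means among the compounds named here.

Compound 1 `CCn1c(C(=O)NCCN)ccc1C(CC)(CC)c1ccc(OCC(=O)C(C)(C)C)c(C)c1` gives 120 nM. Compound 2 `CCn1c(C(=O)N(CCC#N)CCC#N)ccc1C(CC)(CC)c1ccc(OCC(=O)C(C)(C)C)c(C)c1` gives 870 nM. Compound 3 `C#CCCOC(=O)c1ccc(C(CC)(CC)c2ccc(OCC(=O)C(C)(C)C)c(C)c2)n1CC` gives 28800 nM.

In an assay on HL-60 cells for agonist activity at vitamin D3 receptor (Homo sapiens), read by microscopy, with a stated time of 96 h (on this read-out lower numbers stand for an effect already at smaller amounts and higher numbers for an effect only at larger amounts of compound), compound 3 stands highest of the three numbers: its nearest neighbour is compound 2, separated by a 33-fold higher number from compound 2 to compound 3 (1.52 log units; beyond the scatter), and compound 1 lies furthest away, separated by a 240-fold higher number from compound 1 to compound 3 (2.38 log units; beyond the scatter). Compound 4 `CCn1c(C(=O)N(C)CC(=O)O)ccc1C(CC)(CC)c1ccc(OCC(=O)C(C)(C)C)c(C)c1` differs from compound 3 by (carboxymethyl)(methyl)amino in place of (but-3-yn-1-yl)oxy on a carbonyl carbon. Among the measured compounds shown here, both steps that exchange the ester of compound 3 for an amide bear on this change, and both were large, the one to compound 2 less so than the one to compound 1. The step of a 7.3-fold higher number from compound 1 to compound 2 (0.86 log units; beyond the scatter) shows that a tertiary amide remains well placed. Compound 4 is therefore expected to give a markedly lower number, with a 29-fold lower number from compound 3 to compound 4 (1.46 log units; beyond the scatter). The estimate for compound 4 in this assay is 1000 nM, within 150 nM to 8000 nM.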

Compound 4, half-maximal effective concentration: 1390 nM
Estimate against measurement, compound 4: 1.4-fold (0.14 log units) below; low and high end bracket the measured number.
By their numbers in this assay, from the lowest: compound 1; then compounds 2 and 4 (each within the scatter of the next); then compound 3.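

In this assay, an amide bearing (carboxymethyl)(methyl)amino on the carbonyl carbon also stands far from the ester of compound 3 (a 21-fold lower number from compound 3 to compound 4 (1.32 log units; beyond the scatter)), so this position accepts a carboxylic acid at the end of the chain. That acid-bearing tertiary amide and the dinitrile amide cannot be told apart (a 1.6-fold higher number from compound 2 to compound 4 (0.20 log units; within the scatter)), yet compound 1 remains separate from compound 4 (a 12-fold higher number from compound 1 to compound 4 (1.06 log units; beyond the scatter)). No available evidence explains these differences.

The compounds shown leave open whether the amide hydrogen or the terminal amine of compound 1 matters more, which a (2-aminoethyl)(methyl)amino group would separate. They also leave open how a methyl ester of the carboxymethyl chain would compare with the free carboxylic acid.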